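Amide-substituent change on the shared core: anilide to fluoropyridyl amide

This account rests on a few compounds, and the source may have more. Where it says the series, first, only, none or still open, it means among the compounds named here.

Two measured compounds share one core and differ only in the aryl group on the amide nitrogen. Compound 1 `O=C(COc1ccc2cc(/C=C3/SC(=O)NC3=O)ccc2c1)Nc1c(F)cc(F)cc1Br` carries the 2-bromo-4,6-difluorophenyl group; in an assay on isolated protein for inhibition of histone deacetylase 4 (Homo sapiens), with a stated time of 1 h (a lower number here means a stronger inhibitor, a higher number a weaker inhibitor), compound 1 gives 1100 nM. Compound 2 `O=C(COc1ccc2cc(/C=C3/SC(=O)NC3=O)ccc2c1)Nc1ccccc1Oc1ccccc1` carries a phenoxyphenyl group there; in this assay compound 2 gives 5200 nM. Of these two numbers, compound 1 has the lower one, and the gap to compound 2 is beyond the usual scatter. Compound 3 `O=C(COc1ccc2cc(/C=C3/SC(=O)NC3=O)ccc2c1)Nc1cccc(F)n1` is the next member: 6-fluoropyridin-2-yl in place of 2-bromo-4,6-difluorophenyl on an amide-type nitrogen. Within the data shown here, no measured pair covers this change, so the size of the step is open. Among the measured compounds shown here, the only comparison at hand, compound 1 against compound 2, shows that the group on the amide-type nitrogen can move the number well beyond the scatter. The expectation for compound 3 is a moderate loss against compound 1, a step of a 2.3-fold higher number from compound 1 to compound 3 (0.36 log units; beyond the scatter) in this assay, worded as an estimate only. Compound 3 is therefore expected to give about 2500 nM, within a range from 800 nM to 8000 nM.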

Compound 3, half-maximal inhibitory concentration: 840 nM
Beside the measured number, compound 3's estimate is 3.0-fold (0.47 log units) above it; measured number inside the range.
By their numbers in this assay, from the lowest: compounds 3 and 1 (each within the scatter of the next); then compound 2.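

In this assay, the exchange of 2-bromo-4,6-difluorophenyl for 6-fluoropyridin-2-yl on the amide-type nitrogen gives a 1.3-fold lower number from compound 1 to compound 3 (0.12 log units; within the scatter), so this position shows no readable change between these two groups. The earlier pair showed only that this position can move the number; this step shows that the aryl group can lose its bromine and gain a ring hetero atom and a hydrogen-bond acceptor, going from 9 to 7 heavy atoms, while the number stays within the scatter. Among the three compounds, the only gap beyond the scatter at this position still involves the phenoxyphenyl group, with compound 2 at 5200 nM.

No supporting data bear on what lies behind the similar numbers of compound 1 and compound 3. On these data alone, the exchange alters the bromine, the fluorines and the ring hetero atom together, so their separate contributions stay open, as does the outcome with a plain phenyl, an unsubstituted pyridin-2-yl, or a ring carrying an amine or a carboxylic acid.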